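A few compounds are considered here, and "the series" means these few. Any claim that something is new, unique, unknown or untested is made for them only; others in the source may bear on it.

Working notes on the series

The read-out throughout is a functional assay on MCF7 cells (Homo sapiens) for inhibition, read by CCK-8 assay, with a stated time of 48 h; a higher number here means a weaker inhibitor of growth, a lower number a stronger inhibitor of growth. Compound 1 `Cc1ccccc1Nc1nc(Nc2ccc(N3CCN(C)CC3)cn2)ncc1Cl` in this assay gives 5210 nM. Compound 2 `CCN1CCN(c2ccc(Nc3ncc(Cl)c(Nc4ccccc4C)n3)nc2)CC1` is the closest analogue, and its value in this assay is recorded only as a limit, > 100000 nM. The change between the two is methyl in place of hydrogen on a saturated chain carbon bound to an amine nitrogen in a ring, and the step it produced is an at least 19-fold higher number from compound 1 to compound 2 (1.28 log units; beyond the scatter). Compound 3 `Cc1ccccc1Nc1nc(Nc2ccc(N3CCN(C)CC3)cc2)ncc1Cl` gives 20600 nM in this assay, the highest of the two numbers that are not limits; how its core differs from the core of compound 1 is not broken down here.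

Compound 4 `CCN1CCN(c2ccc(Nc3ncc(Cl)c(Nc4ccccc4C)n3)cc2)CC1` has not yet been measured in this assay. Against compound 3 the difference is methyl in place of hydrogen on a saturated chain carbon bound to an amine nitrogen in a ring, which is the same change, at the same place, that separates compound 2 from compound 1. Within the data shown here, the only guide to its effect is the earlier step, an at least 19-fold higher number from compound 1 to compound 2 (1.28 log units; beyond the scatter), and that step is recorded only as a limit, since (the limit of > 100000 nM in this assay, at which 1 of the 3 values shown sits). Starting from the number for compound 3, a step of the same kind would carry compound 4 past that same limit, so the expectation is that compound 4 most likely again returns a limit rather than a number. The step expected from compound 3 to compound 4 is a 7.3-fold higher number from compound 3 to compound 4 (0.86 log units; beyond the scatter). The estimate for compound 4 is therefore 150000 nM, with a range from 40000 nM to 600000 nM.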

Compound 4, concentration for 50% growth inhibition: 3160 nM
The estimate for compound 4 lay 47-fold (1.68 log units) above the measured number; measured number outside the range, below it.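

Within this assay, replacing 4-methylpiperazin-1-yl with 4-ethylpiperazin-1-yl on the core of compound 3 gives a 6.5-fold lower number from compound 3 to compound 4 (0.81 log units; beyond the scatter). The methyl to ethyl change therefore does not carry from one core to the other in this series, and its direction reverses: the same change on two cores in this assay, an at least 19-fold higher number (1.28 log units; beyond the scatter) from compound 1 to compound 2 and a 6.5-fold lower number (0.81 log units; beyond the scatter) from compound 3 to compound 4, at least 120-fold (2.09 log units) apart, beyond the scatter of two such steps. Compound 2 gives > 100000 nM, which is a limit and not a number, so the earlier step has a direction but no fixed size, and these two pairs alone do not show which feature of the cores sets the direction of the change.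

Still open, on these data alone, is whether a longer chain such as propyl, or a 2-hydroxyethyl group, in place of ethyl at the same place would follow the fall in number seen on the core of compound 3 or the rise seen on the core of compound 1. Also open, as far as these compounds go, is whether the same reversal would appear with a different group at that place, such as a carboxylic acid or a primary amine on the chain, and whether it would hold in a read-out on other cells.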